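The source may report more compounds than this note shows. Statements on the series, on what has been measured and on what is new or still open speak of the compounds shown alone.

Measured so far:
compound 1 `C/C(=C\CC/C(C)=C/CC[C@@H]1[C@@]2(C)CCC(=O)C(C)(C)[C@H]2CC[C@@]1(C)O)CC/C=C(\C)C(=O)OCc1cn(-c2ccccc2)nn1` — 95500 nM
compound 2 `C/C(=C\CC/C(C)=C/CC[C@@H]1[C@@]2(C)CCC(=O)C(C)(C)[C@H]2CC[C@@]1(C)O)CC/C=C(\C)C(=O)OCc1cn(-c2ccc([N+](=O)[O-])cc2)nn1` — a limit, > 150000 nM
compound 3 `C/C(=C\CC/C(C)=C/CC[C@@H]1[C@@]2(C)CCC(=O)C(C)(C)[C@H]2CC[C@@]1(C)O)CC/C=C(\C)C(=O)OCc1cn(-c2ccccc2F)nn1` — a limit, > 150000 nM

Among the compounds with values here, in a functional assay on DU-145 cells (Homo sapiens) for antiproliferative activity, read by MTT assay, with a stated time of 48 h (a lower number here means a stronger inhibitor, a higher number a weaker inhibitor), compound 1 gives 95500 nM, the only number in the set. Compound 2 sits at a limit of the assay, > 150000 nM. Compound 3 likewise sits at a limit, > 150000 nM. Both substitutions on the phenyl ring thus end at the limit of > 150000 nM in this assay, at which 2 of the 3 values shown sit: an at least 1.5-fold higher number from compound 1 to compound 2 (0.19 log units; that floor lies within the scatter) and an at least 1.5-fold higher number from compound 1 to compound 3 (0.19 log units; that floor lies within the scatter), while a step that the two limits leave unreadable from compound 2 to compound 3.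

Compound 4 `COc1ccccc1-n1cc(COC(=O)/C(C)=C/CC/C(C)=C/CC/C(C)=C/CC[C@@H]2[C@@]3(C)CCC(=O)C(C)(C)[C@H]3CC[C@@]2(C)O)nn1` carries methoxy in place of hydrogen on an aromatic carbon. The two measured changes on that ring both raised the number, so a similar or higher number is expected for compound 4, with a fair chance the assay again reports only a limit. The expected step is a 1.6-fold higher number from compound 1 to compound 4 (0.20 log units; within the scatter). Compound 4 is estimated at 150000 nM, within 60000 nM to 400000 nM.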

Compound 4, half-maximal inhibitory concentration: > 150000 nM
Compound 4 ended at the assay's limit (the forecaster's own chance of this, stated with the estimate: 55%); the middle value sits exactly at the limit.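

In this assay, methoxy in place of hydrogen on the phenyl ring gives an at least 1.5-fold higher number from compound 1 to compound 4 (0.19 log units; that floor lies within the scatter). The value of compound 4, > 150000 nM, is a limit of the assay and not a number. After the fluoro of compound 3, a second group on this ring carbon ends the same way, and the steps among compound 2, compound 3 and compound 4 cannot be read: the limit of > 150000 nM in this assay, at which 3 of the 4 values shown sit.

Within the data shown here, compound 1 remains the only number, at 95500 nM. Open, as far as these compounds go, is whether an amine or a carboxylic acid on the phenyl ring would give a readable value in this assay.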